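Two Measured Analogues and an Untested Positional Isomer

The source may report more compounds than this note shows. Statements on the series, on what has been measured and on what is new or still open speak of the compounds shown alone.

Measured so far:
compound 1, `CN(C(=O)NC(=O)c1ccc([N+](=O)[O-])cc1)c1nc(C(F)(F)F)c(C(=O)N/N=C/c2cccc(C(F)(F)F)c2)s1`: 1.67 ug/mL
compound 2, `CN(C(=O)NC(=O)c1ccc(F)c(F)c1)c1nc(C(F)(F)F)c(C(=O)N/N=C/c2ccc(C(F)(F)F)cc2)s1`: 3.85 ug/mL

In a functional assay on BCG823 cells (Homo sapiens) for inhibition, read by MTT assay, with a stated time of 72 h (on this read-out higher numbers stand for weaker inhibition and lower numbers for stronger inhibition), compound 2 gives 3.85 ug/mL, the highest of the two numbers shown. Its nearest neighbour is compound 1, which gives 1.67 ug/mL, a gap beyond the usual scatter. Among the measured compounds shown here, since these two differ in more than one place, no single step between them is recorded, and the numbers can only be read side by side. Compound 3, `CN(C(=O)NC(=O)c1ccc(F)c(F)c1)c1nc(C(F)(F)F)c(C(=O)N/N=C/c2cccc(C(F)(F)F)c2)s1`, keeps everything of compound 2 except one change: 3-(trifluoromethyl)phenyl in place of 4-(trifluoromethyl)phenyl on a carbon with a double bond to nitrogen. Compound 1 also carries the 3-(trifluoromethyl)phenyl and returns the lower number, but its further differences from compound 2 mean that number cannot be attributed to the swap alone. The implied step a 1.5-fold lower number from compound 2 to compound 3 (0.17 log units; within the scatter) is expected to be small, toward a lower number, and not clearly beyond the scatter. Compound 3 is therefore estimated at 2.6 ug/mL, within 1.1 ug/mL to 6 ug/mL.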

Compound 3, half-maximal inhibitory concentration: 4.46 ug/mL
Estimate against measurement, compound 3: 1.7-fold (0.23 log units) below; measured number inside the range.
By their numbers in this assay, from the lowest: compound 1; then compounds 2 and 3 (each within the scatter of the next).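

In this assay, the step on the carbon with a double bond to nitrogen, 3-(trifluoromethyl)phenyl in place of 4-(trifluoromethyl)phenyl, is a 1.2-fold higher number from compound 2 to compound 3 (0.06 log units; within the scatter), so with 3,4-difluorophenyl on the carbonyl carbon the two groups cannot be told apart here. Among the compounds shown here, the result also gives the first single-change reading on the carbonyl carbon: 3,4-difluorophenyl in place of 4-nitrophenyl is a 2.7-fold higher number from compound 1 to compound 3 (0.43 log units; beyond the scatter), which ties that gap to this change and not to the 3-(trifluoromethyl)phenyl, which both compounds carry. No measurement at hand accounts for either step.

Going by these compounds, it remains open whether 4-nitrophenyl on the carbonyl carbon would give a similar step alongside 4-(trifluoromethyl)phenyl. Also open, on these data alone, is what an unsubstituted phenyl, a 4-methoxyphenyl or a pyridyl ring would give at either place.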